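Ethoxy in place of hydrogen on compound 2

The compounds below may be only part of what the source reports. "The series", "measured", "known", "first", "only" and "open" are said of these compounds alone.

In a functional assay on NCI-H460 cells (Homo sapiens) for cytotoxicity (a lower number here means a stronger inhibitor, a higher number a weaker inhibitor), compound 2 `O=C(CCCCCCC(=O)Nc1nc2ccccc2s1)NO` gives 5.71 ug/mL, the lowest of the two numbers measured. Compound 1 `COc1ccc2nc(NC(=O)CCCCC(=O)NO)sc2c1` gives 21.4 ug/mL, higher by a gap beyond the scatter. For compound 3 `O=C(CCCCC(=O)Nc1nc2ccc([N+](=O)[O-])cc2s1)NO` the entry > 30 ug/mL is a limit, not a number.

Compound 4 `CCOc1ccc2nc(NC(=O)CCCCCCC(=O)NO)sc2c1` has ethoxy in place of hydrogen on an aromatic carbon of compound 2: ethoxy in place of hydrogen on an aromatic carbon.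

Among the compounds with values here, the only measured single-place step is an at least 1.4-fold higher number from compound 1 to compound 3 (0.14 log units; that floor lies within the scatter). It exchanges nitro for methoxy and does not test adding a group in place of hydrogen, so it bears only indirectly on this change. It also gives only a floor, set by the limit of > 30 ug/mL in this assay, at which 1 of the 3 values shown sits. A small upward step is expected, as compound 1, which carries methoxy, sits at 21.4 ug/mL, although that comparison is weak evidence for ethoxy. The expected change is a 1.4-fold higher number from compound 2 to compound 4 (0.15 log units; within the scatter), and the estimate carries wide uncertainty. For compound 4 the estimated value is 8 ug/mL, with an expected range of 3.5 ug/mL to 20 ug/mL.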

Compound 4, half-maximal inhibitory concentration: 6.58 ug/mL
Beside the measured number, compound 4's estimate is 1.2-fold (0.08 log units) above it; the measured number falls inside the stated range.
By their numbers in this assay, from the lowest: compounds 2 and 4 (each within the scatter of the next); then compound 1. At a limit, above all of these: compound 3.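

Ethoxy in place of hydrogen on an aromatic carbon of the six-membered aromatic ring gives a 1.2-fold higher number from compound 2 to compound 4 (0.06 log units; within the scatter) in this assay, so the two numbers cannot be told apart. Within the data shown here, this is the first step that compares a substituted with an unsubstituted ring and has a real number at both ends, whereas the earlier step exchanged one group for another and gave only a floor. It shows that the core can carry ethoxy at this position without a change beyond the scatter, although nothing shown gives a reason for this step.

As far as these compounds go, whether the same position accepts an amine or a carboxylic acid on this chain remains open. Also open, from the compounds shown here alone, is whether a propoxy or a longer alkoxy chain there would still leave the number within the scatter.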